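Swapping Butyl for Isopropyl on the Carbonyl Carbon

The source may report more compounds than this note shows. Statements on the series, on what has been measured and on what is new or still open speak of the compounds shown alone.

In a functional assay on A-375 cells (Homo sapiens) for cytotoxicity, read by MTT assay (on this read-out lower numbers stand for stronger inhibition and higher numbers for weaker inhibition), compound 1 `COc1ccc(/C=C/C(=O)c2ccc(OC)c3c2OC(C)(C)C=C3)cc1O`, which has hydrogen on the aromatic oxygen, gives 800 nM. Compound 2 `COc1ccc(/C=C/C(=O)c2ccc(OC)c3c2OC(C)(C)C=C3)cc1OCC=C(C)C`, with 3-methylbut-2-en-1-yl on that oxygen, reaches only a limit of the assay, > 10000 nM. Among the compounds with values here, compound 3 `CCCCC(=O)Oc1cc(/C=C/C(=O)c2ccc(OC)c3c2OC(C)(C)C=C3)ccc1OC`, with butylcarbonyl there, gives 220 nM, the lowest number so far, and compound 1 is its nearest measured neighbour.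

Compound 4 `COc1ccc(/C=C/C(=O)c2ccc(OC)c3c2OC(C)(C)C=C3)cc1OC(=O)C(C)C` has not yet been measured. It keeps the shared core and the carbonyl and differs from compound 3 only in the chain: isopropyl in place of butyl on a carbonyl carbon. Within the data shown here, no measured step makes this exact change, but two steps at the same oxygen bear on it. The modest one is a 3.6-fold lower number from compound 1 to compound 3 (0.56 log units; beyond the scatter), and the large one is an at least 12-fold higher number from compound 1 to compound 2 (1.09 log units; beyond the scatter). Compound 4 retains the carbonyl of compound 3, so it is expected to keep most of the modest gain seen in a 3.6-fold lower number from compound 1 to compound 3 (0.56 log units; beyond the scatter) rather than follow the large loss in an at least 12-fold higher number from compound 1 to compound 2 (1.09 log units; beyond the scatter). In this assay, a small upward move is therefore expected for compound 4, a 1.6-fold higher number from compound 3 to compound 4 (0.20 log units; within the scatter), at most slightly beyond the scatter. The estimated value for compound 4 is 350 nM, with an expected range from 140 nM to 900 nM.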

Compound 4, half-maximal inhibitory concentration: 310 nM
Compound 4: middle estimate off by 1.1-fold (0.05 log units), on the high side; low and high end bracket the measured number.
By their numbers in this assay, from the lowest: compounds 3 and 4 (each within the scatter of the next); then compound 1. At a limit, above all of these: compound 2.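

In this assay, isopropyl in place of butyl on a carbonyl carbon gives a 1.4-fold higher number from compound 3 to compound 4 (0.15 log units; within the scatter), so this position tolerates the branched, shorter chain and the two chains cannot be told apart here. The move away from hydrogen on the oxygen now holds for a second carbonyl group, at a 2.6-fold lower number from compound 1 to compound 4 (0.41 log units; beyond the scatter), which makes compound 3 and compound 4 a pair that both lie below compound 1, while compound 2, which carries no carbonyl at this oxygen, goes the other way. The distance from the 3-methylbut-2-en-1-yl group is an at least 32-fold lower number from compound 2 to compound 4 (1.50 log units; beyond the scatter), and this step rests on a limit, not on a number: the limit of > 10000 nM in this assay, at which 1 of the 4 values shown sits.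

The compounds shown leave open how far the chain on the carbonyl carbon can change before the number moves beyond the scatter, as a methyl group, a much longer chain or a phenyl ring in that place might show. They also leave open whether a carbonyl is needed on this oxygen at all, a question that a small methyl group or a chain ending in an amine there could help to settle.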